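The source may report more compounds than this note shows. Statements on the series, on what has been measured and on what is new or still open speak of the compounds shown alone.

Measured so far in a functional assay on HCT-116 cells (Homo sapiens) for antiproliferative activity, read by MTT assay, with a stated time of 72 h; on this read-out higher numbers stand for weaker inhibition and lower numbers for stronger inhibition:
- compound 1 `NC1=NC2(CCOCC2)N(OCCCOc2cc(Cl)c(Cl)cc2Cl)C(N)=N1`: 2750 nM
- compound 2 `Cc1ccc(OCCCON2C(N)=NC(N)=NC23CCOCC3)cc1`: 2390 nM
- compound 3 `NC1=NC2(CCOCC2)N(OCCCOc2ccccc2Cl)C(N)=N1`: 70 nM

Compound 2 has the second highest of the three numbers. The nearest step is a 1.2-fold lower number from compound 1 to compound 2 (0.06 log units; within the scatter), so those two cannot be ordered. Toward compound 3 the step is a 34-fold lower number from compound 2 to compound 3 (1.53 log units; beyond the scatter), and from compound 1 it is a 39-fold lower number from compound 1 to compound 3 (1.59 log units; beyond the scatter).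

Compound 4 `CC(C)(C)c1ccc(OCCCON2C(N)=NC(N)=NC23CCOCC3)cc1` differs from compound 2 by tert-butyl in place of methyl on an aromatic carbon. Within the data shown here, no measured step changes only this group; both steps from compound 2 exchange the entire aryl. Among the measured compounds shown here, the only step that keeps a single para group, a 1.2-fold lower number from compound 1 to compound 2 (0.06 log units; within the scatter), was within the scatter, which gives no grounds for a large move. Compound 4 is therefore expected to show a step of a 1.0-fold higher number from compound 2 to compound 4 (0.02 log units; within the scatter) in this assay, within the scatter. The estimate for compound 4 is 2500 nM, with a range of 800 nM to 8000 nM.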

Compound 4, half-maximal inhibitory concentration: 1610 nM
Beside the measured number, compound 4's estimate is 1.6-fold (0.19 log units) above it; low and high end bracket the measured number.
By their numbers in this assay, from the lowest: compound 3; then compounds 4, 2 and 1 (each within the scatter of the next).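

In this assay, among these compounds, a 1.5-fold lower number from compound 2 to compound 4 (0.17 log units; within the scatter) is the first step that changes only the group on this aromatic carbon. Methyl and tert-butyl cannot be ordered here, so this exchange leaves the read-out unresolved from compound 2 and shows that tert-butyl is accepted at this place on the ring. No measurement on hand bears on this result.

From the compounds shown here alone, whether an amine or a carboxylic acid on this aromatic carbon would give a number in the same range remains open. The alkyl exchange also says nothing about the large steps that replace the entire aryl.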